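Fluoro to trifluoromethyl on two pentafluorosulfanyl anilide cores

This account rests on a few compounds, and the source may have more. Where it says the series, first, only, none or still open, it means among the compounds named here.

Measured compounds:
compound 1, `CC(O)(CSc1ccc(F)cc1)C(=O)Nc1ccc(S(F)(F)(F)(F)F)cc1`, 23000 nM
compound 2, `CC(O)(CSc1ccc(C(F)(F)F)cc1)C(=O)Nc1ccc(S(F)(F)(F)(F)F)cc1`, 24800 nM
compound 3, `CC(O)(CSc1ccc(F)cc1)C(=O)Nc1cccc(S(F)(F)(F)(F)F)c1`, 21900 nM

All three compounds were tested in a functional assay on VCaP cells (Homo sapiens) for antiproliferative activity, read by propidium iodide staining, with a stated time of 96 h; on this read-out lower numbers stand for stronger inhibition and higher numbers for weaker inhibition. Compound 1 and compound 3 are built from the same atoms joined differently; the difference between the two cores is not broken down here, and the values of compound 1 and compound 3 lie within the scatter of each other. Compound 2 differs from compound 1 by trifluoromethyl in place of fluoro on an aromatic carbon and this change gave a 1.1-fold higher number from compound 1 to compound 2 (0.03 log units; within the scatter). Compound 4, `CC(O)(CSc1ccc(C(F)(F)F)cc1)C(=O)Nc1cccc(S(F)(F)(F)(F)F)c1`, differs from compound 3 by trifluoromethyl in place of fluoro on an aromatic carbon which is the same change at the same place, now on the core of compound 3. Because the measured step of a 1.1-fold higher number from compound 1 to compound 2 (0.03 log units; within the scatter) stayed within the scatter, compound 4 is expected to sit close to compound 3, with an estimated step of a 1.1-fold higher number from compound 3 to compound 4 (0.03 log units; within the scatter). Compound 4 is accordingly estimated at 23500 nM in this assay, with an expected range from 12000 nM to 48000 nM.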

Compound 4, half-maximal inhibitory concentration: 27300 nM
For compound 4 the middle estimate is 1.2-fold (0.07 log units) below the measured one; measured number inside the range.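

In this assay the exchange of fluoro for trifluoromethyl on the core of compound 3 gave a 1.2-fold higher number from compound 3 to compound 4 (0.10 log units; within the scatter), and the two cores agree on this change: the same change on two cores in this assay, a 1.1-fold higher number (0.03 log units; within the scatter) from compound 1 to compound 2 and a 1.2-fold higher number (0.10 log units; within the scatter) from compound 3 to compound 4, 1.2-fold (0.06 log units) apart, within the scatter of two such steps. On these two cores, then, the change carried over in the plain sense that it left the number within the scatter on both, so the step read on one core was a fair guide to the step on the other. This does not show that the change has a real effect on either core, since two steps that are each within the scatter say little about how a larger step would transfer, and two cores are no basis for a rule across the series.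

The compounds shown leave open whether a nitrile, a methoxy group or an amine in place of the fluoro would move the number beyond the scatter on either core. They also leave open what a sulfonyl group in place of the chain's sulfur would do.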